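Swapping Chloro for Trifluoromethyl on the Fluorophenyl Ring

The source may hold more compounds than are shown below. What is called first, only, known or untested is meant among the compounds shown, and "the series" means these compounds.

Measured so far in an assay on CHO cells for displacement of a labelled ligand from Melanocortin receptor 4 (Homo sapiens); on this read-out lower numbers stand for stronger inhibition and higher numbers for weaker inhibition:
compound 1 `CC[C@H](NC(C)=O)c1cc(Cl)ccc1C1CCN(C(=O)[C@H]2CN(C(C)(C)C)C[C@@H]2c2ccc(F)cc2F)CC1` gives 640 nM
compound 2 `CC[C@H](NC(C)=O)c1cc(Cl)ccc1C1CCN(C(=O)[C@H]2CN(C(C)(C)C)C[C@@H]2c2ccc(Cl)cc2F)CC1` gives 13.2 nM

Within the data shown here, compound 2 stands at the lowest of these two numbers; its only comparator is compound 1, and the step of a 48-fold lower number from compound 1 to compound 2 (1.69 log units; beyond the scatter) was large. Compound 3 `CC[C@H](NC(C)=O)c1cc(Cl)ccc1C1CCN(C(=O)[C@H]2CN(C(C)(C)C)C[C@@H]2c2ccc(C(F)(F)F)cc2F)CC1` carries trifluoromethyl in place of chloro on an aromatic carbon. Among the measured compounds shown here, no measured step shows this same change, so the single large step bears on it only loosely, and a step of about a 1.1-fold higher number from compound 2 to compound 3 (0.06 log units; within the scatter) in this assay is expected, within the scatter. Compound 3 is therefore estimated at 15 nM, likely between 4 nM and 60 nM.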

Compound 3, half-maximal inhibitory concentration: 9.8 nM
Compound 3: middle estimate off by 1.5-fold (0.18 log units), on the high side; measured number inside the range.
By their numbers in this assay, from the lowest: compounds 3 and 2 (each within the scatter of the next); then compound 1.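

In this assay, trifluoromethyl on this aromatic carbon is not told apart from chloro, with a step within the scatter (a 1.3-fold lower number from compound 2 to compound 3 (0.13 log units; within the scatter)). Against fluoro, trifluoromethyl gives a large step beyond the scatter (a 65-fold lower number from compound 1 to compound 3 (1.81 log units; beyond the scatter)), so the low number seen with chloro is not unique to chloro; of the three groups, fluoro alone stands apart. Nothing available explains these numbers.

Going by these compounds, whether a nitrile, a methoxy group or an amine here would keep the number this low remains open. So does how a bare hydrogen at this position would compare.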